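The compounds below may be only part of what the source reports. "The series", "measured", "known", "first", "only" and "open" are said of these compounds alone.

Compound 1 `COc1ccc(NC(=O)Nc2cc(C)nc3ccccc23)cc1` in an ADME assay on HEK293 cells (Homo sapiens) for cytotoxicity, with a stated time of 72 h (a higher number here means that more compound is needed for the effect, a lower number that less compound is needed), gives > 25000 nM, a limit of the assay rather than a number. Compound 2 `COc1ccc(NC(=O)Nc2cc(C)nc3ccccc23)cc1OC` in this assay likewise gives only the limit > 25000 nM. For the measured compounds named here, the one measured step, a step that the two limits leave unreadable from compound 1 to compound 2, is thus unreadable, and where compound 1 stands is known only as a limit, since (the limit of > 25000 nM in this assay, at which 2 of the 2 values shown sit). Compound 3 `Cc1cc(NC(=O)Nc2ccc(OC(F)(F)F)cc2)c2ccccc2n1` differs from compound 1 by trifluoromethyl in place of methyl on an oxygen on an aromatic ring. Going by the values given here, no measured step bears on this change, and no step beyond the scatter can be expected in this assay. Compound 3 is expected near 30000 nM in this assay, between 10000 nM and 100000 nM. The step this estimate means, a step that the limit leaves unreadable from compound 1 to compound 3, is expected to stay unreadable at the limit.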

Compound 3, half-maximal effective concentration: 14000 nM
Compound 3: the middle estimate sits 2.1-fold (0.33 log units) above what was measured, within the range that was stated.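

Trifluoromethoxy in place of methoxy gives the first step in the series with any readable size in this assay, and it is only a floor: an at least 1.7-fold lower number from compound 1 to compound 3 (0.25 log units; that floor lies within the scatter). For the compounds shown here, compound 3 is also the first compound with a value that is a number rather than a limit, 14000 nM. The full size of the step stays unknown because compound 1 is held at a limit: the limit of > 25000 nM in this assay, at which 2 of the 3 values shown sit.

As far as these compounds go, whether this step exceeds the scatter remains open. So does the result in this assay for an amine or a carboxylic acid in place of the methoxy.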